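Dihydrofuran amides: a methyl on the benzylamide ring

The source may report more compounds than this note shows. Statements on the series, on what has been measured and on what is new or still open speak of the compounds shown alone.

Measured compounds:
compound 1, `C=CC1=C(C(=O)NCc2ccccc2)C(c2ccc(OC)c(OC)c2)OC1`: > 100000 nM
compound 2, `C=CC1=C(C(=O)NCc2ccccc2)C(c2ccc(OC)cc2)OC1`: > 100000 nM
compound 3, `C=CC1=C(C(=O)Nc2ccccc2)C(c2ccc(F)cc2)OC1`: > 100000 nM

In a functional assay on HeLa cells (Homo sapiens) for cytotoxicity, read by MTT assay, with a stated time of 24 h (on this read-out lower numbers stand for stronger inhibition and higher numbers for weaker inhibition), compound 1 gives > 100000 nM, which is a limit of the assay and not a number. Compound 2 gives > 100000 nM in this assay, again a limit. Compound 3 gives > 100000 nM in this assay, also a limit. Compound 1 therefore stands nowhere in particular on a scale: every value shown sits at the limit of > 100000 nM in this assay, at which 3 of the 3 values shown sit, and nothing separates the three compounds. Among the measured compounds shown here, only one step joins two neighbours, and a step that the two limits leave unreadable from compound 1 to compound 2 cannot be sized, both of its ends being limits.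

Compound 4, `C=CC1=C(C(=O)NCc2ccc(C)cc2)C(c2ccc(OC)c(OC)c2)OC1`, has not been measured in this assay. It differs from compound 1 by methyl in place of hydrogen on an aromatic carbon. No measured step bears on this change: the single step shown concerns a methoxy group and is itself unreadable. With three limits and no readable step, no direction can be argued and nothing beyond the scatter is expected. Compound 4 is expected to remain at the limit, estimated at 150000 nM with a range from 50000 nM to 500000 nM. The step that the limit leaves unreadable from compound 1 to compound 4 that this estimate implies is expected to be unreadable in the same way.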

Compound 4, half-maximal inhibitory concentration: > 100000 nM
Compound 4 gave a limit, no number; the forecaster's own chance of this, stated with the estimate: 85%; the middle value does not contradict the limit.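

Compound 4 gives > 100000 nM in this assay as a limit of the assay and not a number. Compound 1 also stands at a limit, so no step from compound 1 to compound 4 can be read, and the four compounds share one position: the limit of > 100000 nM in this assay, at which 4 of the 4 values shown sit.

The compounds shown leave open whether any change to the shared core gives a readable value in this assay at all.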